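The source may report more compounds than this note shows. Statements on the series, on what has been measured and on what is new or still open speak of the compounds shown alone.

In an ADME assay on MCF7 cells (Homo sapiens) for cytotoxicity, read by MTT assay, with a stated time of 48 h (on this read-out lower numbers stand for stronger inhibition and higher numbers for weaker inhibition), compound 2 `Fc1ccc2c(Cn3cncn3)c(-c3ccc(Cl)cc3)[nH]c2c1` gives > 1000000 nM, which is a limit of the assay and not a number. Compound 1 `Fc1ccc(-c2[nH]c3cc(F)ccc3c2Cn2cncn2)cc1` gives > 1000000 nM, again a limit. Compound 3 `COc1ccc(-c2[nH]c3cc(F)ccc3c2Cn2cncn2)cc1` gives a true number, 325000 nM. Compound 4 `COc1ccc2c(Cn3cncn3)c(-c3ccc(Cl)cc3)[nH]c2c1` differs from compound 2 by methoxy in place of fluoro on an aromatic carbon. The same exchange at a different aromatic carbon gave an at least 3.0-fold lower number from compound 1 to compound 3 (0.48 log units; beyond the scatter), and methoxy in place of chloro gave an at least 3.0-fold lower number from compound 2 to compound 3 (0.48 log units; beyond the scatter). As far as these compounds go, both steps lie beyond the scatter, but both start from a limit, so their full size is unknown. A lower number is therefore expected, and the expected step is an at least 2.2-fold lower number from compound 2 to compound 4 (0.34 log units; beyond the scatter). For compound 4 the estimated value is 450000 nM, with an expected range from 150000 nM to 1000000 nM.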

Compound 4, half-maximal inhibitory concentration: 612000 nM
Compound 4: middle estimate off by 1.4-fold (0.13 log units), on the low side; the measured number falls inside the stated range.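

In this assay, among these compounds, methoxy in place of fluoro on this aromatic carbon gives an at least 1.6-fold lower number from compound 2 to compound 4 (0.21 log units; that floor lies within the scatter), so a second methoxy exchange, at a different place from the one on compound 1, also yields a true number, although the floor of this step does not clear the scatter. Whether the exchange counts for the same on both cores cannot be told: the same change on two cores in this assay, an at least 3.0-fold lower number (0.48 log units; beyond the scatter) from compound 1 to compound 3 and an at least 1.6-fold lower number (0.21 log units; that floor lies within the scatter) from compound 2 to compound 4; the limit leaves it open whether they differ

As far as these compounds go, the true size of these steps stays open: the limit of > 1000000 nM in this assay, at which 2 of the 4 values shown sit. Also open is how an amine or a longer chain such as ethoxy on this aromatic carbon would compare with methoxy.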